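A Methyl Added to the Ester Chain

This account rests on a few compounds, and the source may have more. Where it says the series, first, only, none or still open, it means among the compounds named here.

Three compounds have been measured in an assay on cells for displacement of a labelled ligand from adenosine receptor A1 (Homo sapiens), with a stated time of 60 min, tested at 1 uM; on this read-out higher numbers stand for more inhibition at the one concentration tested (going by the name of the read-out) and lower numbers for less inhibition:
- compound 1 `CCOC(=O)C1=C(C)N/C(=N\C#N)NC1c1cccs1` gives 26%
- compound 2 `CCOC(=O)C1=C(C)N/C(=N\C#N)NC1c1ccsc1` gives 29%
- compound 3 `CCOC(=O)C1=C(C)N/C(=N\C#N)NC1C1CCCC1` gives 11%

Among these three numbers compound 1 stands second highest. Its nearest neighbour is compound 2, reached by a number 3 percentage points higher from compound 1 to compound 2 (within the scatter), a step that lies within the scatter. Its furthest neighbour is compound 3, reached by a number 15 percentage points lower from compound 1 to compound 3 (beyond the scatter). The same direction is seen with a number 18 percentage points lower from compound 2 to compound 3 (beyond the scatter). All three measured steps change only the group on the saturated ring carbon of the shared core.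

Compound 4 `CC1=C(C(=O)OC(C)C)C(c2cccs2)N/C(=N/C#N)N1` differs from compound 1 in a different place: methyl in place of hydrogen on a saturated chain carbon bound to an oxygen next to a carbonyl group and a saturated chain carbon. For the measured compounds named here, no measured step touches the ester chain, so none of the three steps bears directly on this change. In the absence of any step on that part of the structure, the expectation is a step no larger than the scatter, no change at the digits printed from compound 1 to compound 4 (within the scatter), in either direction. On that basis compound 4 is estimated at 26%, with a range from 12% to 40%.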

Compound 4, a percentage reported as inhibition, at one concentration (the size of the read-out at that concentration, not a potency): 31%
For compound 4 the middle estimate is 5 percentage points below the measured one, and the stated range covers the measured number.
By their numbers in this assay, from the lowest: compound 3; then compounds 1, 2 and 4 (each within the scatter of the next).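

For the compounds shown here, this is the first measured step on the ester chain rather than on the group at the saturated ring carbon: in this assay, ethoxy to isopropoxy gives a number 5 percentage points higher from compound 1 to compound 4 (within the scatter) on the core of compound 1. At the one concentration tested, the added methyl on this saturated chain carbon therefore leaves no difference that can be told from the scatter, so this part of the structure accepts this small change, whereas the cyclopentyl change at the ring carbon gave a step beyond the scatter. Nothing shown here offers an explanation for this result.

The compounds shown leave open whether a longer chain on the ester oxygen, such as butyl, or a carboxylic acid in place of the ester would read the same. They also leave open whether the isopropyl ester would behave alike with thiophen-3-yl or cyclopentyl on the ring carbon.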